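This account rests on a few compounds, and the source may have more. Where it says the series, first, only, none or still open, it means among the compounds named here.

In an ADME assay on microsomes (Mus musculus) for metabolic stability (on this read-out lower numbers stand for slow clearance and higher numbers for fast clearance), compound 3 (`Cc1cc(C(F)(F)F)c2cccc(OCc3c(Cl)ccc(S(=O)(=O)N4CCCC4)c3Cl)c2n1`) gives 967 mL/min/kg as the second highest of three numbers. In the same read-out compound 1 (`Cc1cc(C(F)(F)F)c2cccc(OCc3c(Cl)ccc(S(=O)(=O)N4CCC[C@H]4C(N)=O)c3Cl)c2n1`) gives 12600 mL/min/kg, and compound 2 (`Cc1cc(C(F)(F)F)c2cccc(OCc3c(Cl)ccc(S(=O)(=O)N4CCC[C@H]4C(=O)O)c3Cl)c2n1`) gives 13.3 mL/min/kg. Compound 4 (`Cc1cc(C(F)(F)F)c2cccc(OCc3c(Cl)ccc(S(=O)(=O)N4CCC(CCO)CC4)c3Cl)c2n1`) differs from compound 3 as follows (4-(2-hydroxyethyl)piperidin-1-yl in place of pyrrolidin-1-yl on a sulfonyl sulfur): 4-(2-hydroxyethyl)piperidin-1-yl in place of pyrrolidin-1-yl on a sulfonyl sulfur. For the measured compounds named here, two measured steps touch that group: a 13-fold lower number from compound 1 to compound 3 (1.11 log units; beyond the scatter) on losing carbamoyl and a 73-fold higher number from compound 2 to compound 3 (1.86 log units; beyond the scatter) on losing carboxy, both large and opposite in direction. Neither replaces the ring, and no hydroxyethyl chain has been measured so far, so no direction can be read from them. The expected step in this assay is none beyond the scatter (a 1.4-fold lower number from compound 3 to compound 4 (0.14 log units; within the scatter)), with a wide margin. Compound 4 is estimated at 700 mL/min/kg within a range of 150 mL/min/kg to 3000 mL/min/kg in this assay for now.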

Compound 4, clearance: 1080 mL/min/kg
Compound 4: middle estimate off by 1.5-fold (0.19 log units), on the low side, and the stated range covers the measured number.
By their numbers in this assay, from the lowest: compound 2; then compounds 3 and 4 (each within the scatter of the next); then compound 1.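

In this assay, the step to 4-(2-hydroxyethyl)piperidin-1-yl on the sulfonyl sulfur stays within the scatter, with a 1.1-fold higher number from compound 3 to compound 4 (0.05 log units; within the scatter), so this position accepts a six-membered ring carrying a hydroxyethyl chain with no shift from the unsubstituted pyrrolidin-1-yl. The large gaps to the substituted pyrrolidines remain, with an 81-fold higher number from compound 2 to compound 4 (1.91 log units; beyond the scatter) and a 12-fold lower number from compound 1 to compound 4 (1.07 log units; beyond the scatter), so the hydroxyl of compound 4 does not reproduce the carboxy or carbamoyl result. No measurement here explains these numbers.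

Ring size and the hydroxyethyl chain change together, so their separate contributions remain open. From the compounds shown here alone, an amine or a carboxylic acid at the end of that chain also remains open.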